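A few compounds are considered here, and "the series" means these few. Any claim that something is new, unique, unknown or untested is made for them only; others in the source may bear on it.

Compound 1 `C=C1C(=O)[C@@]23C(=O)OC[C@]4([C@@H](OC(C)=O)CCC(C)(C)[C@H]4C=O)[C@@H]2CC[C@H]1[C@H]3OC(=O)c1ccc(OC)cc1` and compound 2 `C=C1C(=O)[C@@]23C(=O)OC[C@]4([C@@H](OC(C)=O)CCC(C)(C)[C@H]4C=O)[C@@H]2CC[C@H]1[C@H]3OC(=O)c1ccccc1` share one core and differ only at the aromatic ring of the ester. In a functional assay on K562 cells (Homo sapiens) for inhibition, read by MTT assay (on this read-out lower numbers stand for stronger inhibition and higher numbers for weaker inhibition), compound 1 gives 1920 nM, and compound 2 gives 1400 nM; the step of a 1.4-fold lower number from compound 1 to compound 2 (0.14 log units; within the scatter) lies within the scatter, so compound 2 stands together with compound 1 rather than apart from it. Compound 3 `C=C1C(=O)[C@@]23C(=O)OC[C@]4([C@@H](OC(C)=O)CCC(C)(C)[C@H]4C=O)[C@@H]2CC[C@H]1[C@H]3OC(=O)c1ccc(C)cc1` carries methyl in place of hydrogen on an aromatic carbon. Among the compounds with values here, only the step from compound 1 to compound 2 bears on this change, and it was small, so no step beyond the scatter is expected in this assay: compound 3 is expected to give 1400 nM (range 700 nM to 2800 nM), a change of no change at the digits printed from compound 2 to compound 3 (within the scatter).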

Compound 3, half-maximal inhibitory concentration: 1310 nM
Compound 3: middle estimate off by 1.1-fold (0.03 log units), on the high side; the range from low to high includes it.
By their numbers in this assay, from the lowest: compounds 3, 2 and 1 (each within the scatter of the next).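

In this assay, the position para to a large group now holds a third substituent, and the steps remain small: a 1.1-fold lower number from compound 2 to compound 3 (0.03 log units; within the scatter) and a 1.5-fold lower number from compound 1 to compound 3 (0.17 log units; within the scatter) are both printed as within the scatter. Hydrogen, methyl and methoxy at this position therefore cannot be told apart on this read-out.

On these data alone, whether an amine, a carboxylic acid or a longer chain at this position would give a step beyond the scatter stays open. Nothing at hand speaks to a cause for these small steps.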